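This account rests on a few compounds, and the source may have more. Where it says the series, first, only, none or still open, it means among the compounds named here.

Measured so far:
compound 1, `CC[C@@H](Nc1c(C#N)c(-c2ccc(-c3cccnc3C)cc2)nc2cnccc12)C(N)=O`, with 1.9;
compound 2, `CC[C@@H](Nc1c(C#N)c(-c2ccc(-c3ccccc3C(F)(F)F)cc2)nc2cnccc12)C(N)=O`, with 3.1.

Both values come from a physicochemical assay for lipophilicity, read by HPLC, at pH 7.5; on this read-out higher numbers stand for higher lipophilicity and lower numbers for lower lipophilicity. Among the measured compounds shown here, compound 2 stands at the top of these two numbers, and its only neighbour is compound 1, which lies a number 1.20 log units higher from compound 1 to compound 2 (beyond the scatter). That single step shows how much the group on this aromatic carbon can move this assay.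

Compound 3, `CC[C@@H](Nc1c(C#N)c(-c2ccc(Br)cc2)nc2cnccc12)C(N)=O`, has not yet been measured. It differs from compound 2 in one place: bromo in place of 2-(trifluoromethyl)phenyl on an aromatic carbon. For the measured compounds named here, no measured step replaces an aromatic group by a single bromine, so the step from compound 1 to compound 2 is only an indirect guide to the size of change such a swap can bring. A drop is expected, since bromo takes the place of 2-(trifluoromethyl)phenyl; in this assay compound 3 is expected to show a number 1.40 log units lower from compound 2 to compound 3 (beyond the scatter). For compound 3 the estimate is 1.7, within a range from 1.2 to 2.3.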

Compound 3, distribution coefficient: 2.2
Beside the measured number, compound 3's estimate is 0.50 log units below it; the measured number falls inside the stated range.
By their numbers in this assay, from the lowest: compounds 1 and 3 (each within the scatter of the next); then compound 2.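

In this assay, the change gives a number 0.90 log units lower from compound 2 to compound 3 (beyond the scatter) when a single bromine atom replaces a group of 10 heavy atoms that carries an aromatic ring, so a ring is not required at this position for a reading near those of the other compounds. Bromo in place of 2-methylpyridin-3-yl gives a number 0.30 log units higher from compound 1 to compound 3 (within the scatter), so compound 1 and compound 3 cannot be told apart here, even though one group is a ring and the other a lone atom, and the number of heavy atoms alone does not set the reading. No measurement shown here explains these readings.

Still open, as far as these compounds go, is how an amine, a carboxylic acid or a longer chain would read on this aromatic carbon. Also open, from the compounds shown here alone, is whether a group with a ring but no fluorine would stay close to compound 1 or move towards compound 2.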